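Substituent changes on the thiazole-bearing position in the series

The compounds below may be only part of what the source reports. "The series", "measured", "known", "first", "only" and "open" are said of these compounds alone.

Among the measured compounds shown here, compound 3 `CSc1cnc(NC(=O)[C@H](c2ccc(Cl)cc2)C(C)(C)C)s1` stands highest of the three numbers so far in a functional assay on CHO cells for agonist activity at Free fatty acid receptor 2 (Homo sapiens), read by cAMP accumulation (on this read-out higher numbers stand for larger maximal responses and lower numbers for smaller maximal responses), where compound 3 gives 109%. Its nearest neighbour is compound 2 `CC(C)(C)[C@H](C(=O)Nc1ncc(F)s1)c1ccc(Cl)cc1`, which in this assay gives 92%; the furthest is compound 1 `CC(C)[C@H](C(=O)Nc1ncc(C(N)=O)s1)c1ccc(Cl)cc1`, which in this assay gives 59%. Compound 1 differs from the others in two places, so only its value itself is shown. For the measured compounds named here, the single-site step a number 17 percentage points higher from compound 2 to compound 3 (beyond the scatter) is the one measured change at the aromatic carbon next to the ring sulfur, and it lies beyond the scatter.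

Compound 4 `CN1CCN(c2cnc(NC(=O)[C@H](c3ccc(Cl)cc3)C(C)(C)C)s2)CC1` continues at the same place: 4-methylpiperazin-1-yl in place of methylsulfanyl on an aromatic carbon. Going by the values given here, the only step that bears on it is a number 17 percentage points higher from compound 2 to compound 3 (beyond the scatter), which shows that this position carries a change of modest size; the entering group is far larger than anything measured, so the direction is open. A small downward step is expected, a number 17 percentage points lower from compound 3 to compound 4 (beyond the scatter), within or near the scatter. Compound 4 is thus expected to give 92% in this assay, with a range of 60% to 115%.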

Compound 4, largest response reached (reported as efficacy), in percent of the reference or control that the assay uses: 113%
For compound 4 the middle estimate is 21 percentage points below the measured one; the range from low to high includes it.
By their numbers in this assay, from the lowest: compound 1; then compound 2; then compounds 3 and 4 (each within the scatter of the next).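

In this assay, the exchange of methylsulfanyl for 4-methylpiperazin-1-yl on the aromatic carbon next to the ring sulfur gives a number 4 percentage points higher from compound 3 to compound 4 (within the scatter), so a group with a six-membered non-aromatic ring and many more heavy atoms is accommodated here with no separation from the smaller group. Against fluoro, the same ring gives a number 21 percentage points higher from compound 2 to compound 4 (beyond the scatter), and together with a number 17 percentage points higher from compound 2 to compound 3 (beyond the scatter) this places fluoro apart from both larger groups, in the same direction. No available evidence bears on the reason for this result.

Steps to compound 1 cannot be read, as it differs from the others in two places, so the effect of its carboxamide stays unresolved. Also open, from the compounds shown here alone, is how a morpholine ring, a primary amine or a carboxylic acid at this carbon would compare.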